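Lengthening the amine-bearing chain of compound 3

The source may hold more compounds than are shown below. What is called first, only, known or untested is meant among the compounds shown, and "the series" means these compounds.

Measured so far:
compound 1 `NCc1c[nH]c2ccc(F)cc12`, a limit of the assay: > 1000 nM
compound 2 `CN1CCN(Cc2c[nH]c3ccc(F)cc23)CC1`, a limit of the assay: > 1000 nM
compound 3 `CCNCCCc1c[nH]c2ccc(F)cc12`: 190 nM

Within the data shown here, in an assay on isolated protein for inhibition of Myeloperoxidase (Homo sapiens) (a lower number here means a stronger inhibitor, a higher number a weaker inhibitor), compound 3 holds the only number among the three; the other two values are limits of the assay, (the limit of > 1000 nM in this assay, at which 2 of the 3 values shown sit). The step of an at least 5.2-fold lower number from compound 1 to compound 3 (0.72 log units; beyond the scatter) can only be given as a lower bound because of the limit of > 1000 nM in this assay, at which 2 of the 3 values shown sit, but it shows that replacing the short aminomethyl arm by a longer chain carrying an ethyl group on its nitrogen made the inhibitor clearly stronger.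

Compound 4 `NCCCCCCc1c[nH]c2ccc(F)cc12` differs from compound 3 by 3-aminopropyl in place of ethylamino on a saturated chain carbon, three bonds along the chain from an aromatic carbon. It keeps a long chain, which the step from compound 1 to compound 3 favoured, yet it returns to a plain amine at the chain end, as in compound 1. Among the measured compounds shown here, no measured step separates those two aspects, so the expectation is a step near or slightly beyond the scatter toward a weaker inhibitor, a 1.8-fold higher number from compound 3 to compound 4 (0.27 log units; within the scatter). The estimate for compound 4 in this assay is 350 nM, with a likely range from 90 nM to 1500 nM.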

Compound 4, half-maximal inhibitory concentration: 580 nM
Estimate against measurement, compound 4: 1.7-fold (0.22 log units) below; measured number inside the range.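

The change from ethylamino to 3-aminopropyl gives a 3.1-fold higher number from compound 3 to compound 4 (0.48 log units; beyond the scatter), so a long chain alone does not preserve the strength seen in compound 3. Compound 4 keeps a long chain but ends in a plain amine, and it is the weaker inhibitor of the pair. This single change both removes the ethyl group from the nitrogen and moves the nitrogen further out along the chain, so the step cannot show which of the two matters more.

Going by these compounds, it remains open whether an ethylamino group at the end of the longer chain of compound 4, or a plain amine on the shorter chain of compound 3, would recover or lose strength. How compound 4 stands against compound 1 and compound 2 cannot be read as a step: the limit of > 1000 nM in this assay, at which 2 of the 4 values shown sit.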